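Chlorobenzimidazole rhodanines: a benzyl swap repeated

The compounds below may be only part of what the source reports. "The series", "measured", "known", "first", "only" and "open" are said of these compounds alone.

This account covers three measured compounds and one that still awaits measurement. Compound 1 `Cc1ccc(Cn2c(/C=C3\SC(=S)N(CC(=O)O)C3=O)nc3cc(Cl)ccc32)cc1` and compound 2 `Cc1ccc(Cn2c(/C=C3\SC(=S)N(CC(=O)O)C3=O)nc3ccc(Cl)cc32)cc1` share the same atoms joined differently; the difference between the two cores is not broken down here. Compound 3 `O=C(O)CN1C(=O)/C(=C/c2nc3cc(Cl)ccc3n2Cc2ccccc2F)SC1=S` carries the core of compound 1, and compound 4 `O=C(O)CN1C(=O)/C(=C/c2nc3ccc(Cl)cc3n2Cc2ccccc2F)SC1=S` carries the core of compound 2. In a functional assay on HeLa cells (Homo sapiens) for cytotoxicity, read by MTT assay, with a stated time of 48 h (a higher number here means a weaker inhibitor, a lower number a stronger inhibitor), compound 1 gives 21400 nM, compound 2 gives 11000 nM, and compound 3 gives 9520 nM.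

Within the data shown here, the one change that is measured is 2-fluorophenyl in place of 4-methylphenyl on a saturated chain carbon bound to an aromatic nitrogen, and it produced a 2.2-fold lower number from compound 1 to compound 3 (0.35 log units; beyond the scatter). Among the measured compounds shown here, the values of compound 2 and compound 3 lie within the scatter of each other, as do those of compound 2 and compound 1, so no order among those pairs is claimed.

The same change, (2-fluorophenyl in place of 4-methylphenyl on a saturated chain carbon bound to an aromatic nitrogen), leads from compound 2 to compound 4. Because the step of a 2.2-fold lower number from compound 1 to compound 3 (0.35 log units; beyond the scatter) was modest but beyond the scatter, the expectation for compound 4 rests on that single precedent, carried over to a different core. Whether the second core answers the change in the same way is not known from these data. Compound 4 is expected to show a 2.0-fold lower number from compound 2 to compound 4 (0.30 log units; within the scatter) in this assay. Compound 4 is therefore estimated at 5500 nM, with a range from 2500 nM to 12000 nM.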

Compound 4, half-maximal inhibitory concentration: 7620 nM
Beside the measured number, compound 4's estimate is 1.4-fold (0.14 log units) below it; low and high end bracket the measured number.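

In this assay, replacing 4-methylbenzyl with 2-fluorobenzyl on the core of compound 2 gives a 1.4-fold lower number from compound 2 to compound 4 (0.16 log units; within the scatter), so this step alone does not separate the two compounds on that core. Set beside the earlier step on the core of compound 1, the result shows no measurable difference in how the two cores answer the change: the same change on two cores in this assay, a 2.2-fold lower number (0.35 log units; beyond the scatter) from compound 1 to compound 3 and a 1.4-fold lower number (0.16 log units; within the scatter) from compound 2 to compound 4, 1.6-fold (0.19 log units) apart, within the scatter of two such steps. This agrees with the change carrying over from one core to the other, but it does not establish an equal effect, since each core offers a single pair and the step on the core of compound 2 is itself within the scatter; a real difference of modest size between the cores could go unseen in these data.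

The compounds shown leave open whether the same carry-over would hold for other groups on that saturated chain carbon, such as an unsubstituted benzyl or a chlorobenzyl, and whether it would survive on a core with the chlorine replaced by a methoxy group. They also leave open how the series would read with a methyl ester or a primary amide in place of the carboxylic acid.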